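The source may report more compounds than this note shows. Statements on the series, on what has been measured and on what is new or still open speak of the compounds shown alone.

The measured compounds:

Compound 1, `COc1cc(/C=C/C(=O)/C=C/c2nc3ccccc3n2C)ccc1O`, gives 4700 nM in a functional assay on SH-SY5Y cells (Homo sapiens) for cytotoxicity, read by MTT assay, with a stated time of 48 h; a lower number here means a stronger inhibitor, a higher number a weaker inhibitor.
Compound 2, `COc1cc(/C=C/C(=O)/C=C/c2nc3cc(C)ccc3n2C)ccc1O`, gives 4700 nM in this assay.
Compound 3, `COc1ccc(/C=C/C(=O)/C=C/c2nc3c(C)cccc3n2C)cc1O`, gives 19100 nM in this assay.

Compound 1 and compound 2 differ in one place, (methyl in place of hydrogen on an aromatic carbon), and that change made a step of no change at the digits printed from compound 1 to compound 2 (within the scatter). Compound 3 has a different core from compound 1, and the difference between the two cores is not broken down here; its value stands highest of the three, and the gap to compound 1 and to compound 2 lies beyond the scatter.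

Compound 4, `COc1ccc(/C=C/C(=O)/C=C/c2nc3c(C)c(C)ccc3n2C)cc1O`, has not been measured. It differs from compound 3 in one place, (methyl in place of hydrogen on an aromatic carbon). Among the compounds with values here, this is the same kind of change as the one from compound 1 to compound 2, but not the same: the new methyl in compound 4 sits ortho to a methyl group (1 heavy atom), which the place in compound 2 does not.

Compound 4 is expected to give about 19000 nM in this assay, because no change at the digits printed from compound 1 to compound 2 (within the scatter). The expected step is a 1.0-fold lower number from compound 3 to compound 4 (0.00 log units; within the scatter), resting on that earlier step and on compound 3 and its value 19100 nM. The range for compound 4 is expected to run from 9000 nM to 40000 nM.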

Compound 4, half-maximal inhibitory concentration: 4800 nM
Beside the measured number, compound 4's estimate is 4.0-fold (0.60 log units) above it, and the stated range ends above it.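

In this assay, putting a methyl in place of hydrogen on an aromatic carbon brought a 4.0-fold lower number from compound 3 to compound 4 (0.60 log units; beyond the scatter), a modest step. Within the data shown here, the same change therefore did not carry over with the same size from one core to the other: the same change on two cores in this assay, no change at the digits printed (within the scatter) from compound 1 to compound 2 and a 4.0-fold lower number (0.60 log units; beyond the scatter) from compound 3 to compound 4, 4.0-fold (0.60 log units) apart, beyond the scatter of two such steps This comparison rests on only one pair of compounds for each core, and the new methyl in compound 4 sits ortho to a methyl group, which the new methyl in compound 2 does not, so these results cannot separate the effect of the core from the effect of that particular place, and they give no reason for the gap between the two steps.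

The compounds shown leave open whether the step seen for compound 4 depends on the existing methyl group or would appear at the same place on the core of compound 1. They also leave open how a different group at that place, such as an ethyl group, a chlorine atom or an amine, would compare with the methyl in this cell assay.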